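Shrinking the side chain further: from methyl to hydrogen

The compounds below may be only part of what the source reports. "The series", "measured", "known", "first", "only" and "open" are said of these compounds alone.

Of the compounds shown here, three sharing one core have been measured in a functional assay on HL-60 cells (Homo sapiens) for antiproliferative activity, read by MTT assay, with a stated time of 48 h (a higher number here means a weaker inhibitor, a lower number a stronger inhibitor), differing only in the group on a saturated chain carbon bound to an amide-type nitrogen and a carbonyl carbon. Compound 1 `CC(C)[C@H](NC(=O)c1ccc(C(=O)Nc2ccc3c(c2)C(C)(C)CCC3(C)C)cc1)C(=O)OCc1c(-c2ccccc2)no[n+]1[O-]` carries an isopropyl there and gives 5850 nM. Compound 2 `CC(C)C[C@H](NC(=O)c1ccc(C(=O)Nc2ccc3c(c2)C(C)(C)CCC3(C)C)cc1)C(=O)OCc1c(-c2ccccc2)no[n+]1[O-]` carries an isobutyl and gives 740 nM, a step of a 7.9-fold lower number from compound 1 to compound 2 (0.90 log units; beyond the scatter). Compound 3 `C[C@H](NC(=O)c1ccc(C(=O)Nc2ccc3c(c2)C(C)(C)CCC3(C)C)cc1)C(=O)OCc1c(-c2ccccc2)no[n+]1[O-]` carries a methyl and gives 6970 nM, the highest of the three numbers; against compound 1 the step is a 1.2-fold higher number from compound 1 to compound 3 (0.08 log units; within the scatter), against compound 2 it is a 9.4-fold higher number from compound 2 to compound 3 (0.97 log units; beyond the scatter).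

Compound 4 `CC1(C)CCC(C)(C)c2cc(NC(=O)c3ccc(C(=O)NCC(=O)OCc4c(-c5ccccc5)no[n+]4[O-])cc3)ccc21` takes this one step further: hydrogen in place of methyl on a saturated chain carbon bound to an amide-type nitrogen and a carbonyl carbon. Going by the values given here, two steps bear on it. Shrinking from isopropyl to methyl, from compound 1 to compound 3, stayed within the scatter, while removing the isopropyl of compound 2 raised the number beyond it. A further shrink is therefore expected to change little, with perhaps a slight rise in this assay: the estimated step is a 1.2-fold higher number from compound 3 to compound 4 (0.09 log units; within the scatter). Compound 4 is expected to give about 8500 nM, within a range from 3500 nM to 22000 nM.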

Compound 4, half-maximal inhibitory concentration: 160 nM
Estimate against measurement, compound 4: 53-fold (1.73 log units) above; the whole stated range lies above it.
By their numbers in this assay, from the lowest: compound 4; then compound 2; then compounds 1 and 3 (each within the scatter of the next).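

Removing the methyl gives the largest step seen at this position, a 44-fold lower number from compound 3 to compound 4 (1.64 log units; beyond the scatter), and the hydrogen also outdoes the two other groups, with a 37-fold lower number from compound 1 to compound 4 (1.56 log units; beyond the scatter) and a 4.6-fold lower number from compound 2 to compound 4 (0.67 log units; beyond the scatter), which makes compound 4 the strongest of the four. The numbers therefore do not follow the growth of the group in one direction: hydrogen and isobutyl give the two lowest numbers, while methyl and isopropyl, within the scatter of each other, both sit above them. The effect of putting hydrogen in place of isopropyl also does not carry over from one case to another: the same change on two cores in this assay, a 9.4-fold higher number (0.97 log units; beyond the scatter) from compound 2 to compound 3 and a 37-fold lower number (1.56 log units; beyond the scatter) from compound 1 to compound 4, 340-fold (2.54 log units) apart, beyond the scatter of two such steps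

On these data alone, how a longer straight chain, a benzyl group or an amine on this carbon would behave remains open. So does whether isobutyl is an isolated low point among the groups larger than hydrogen.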